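Chloro on the phenyl group of compound 2

A few compounds are considered here, and "the series" means these few. Any claim that something is new, unique, unknown or untested is made for them only; others in the source may bear on it.

Of the compounds shown here, two carry numbers so far. In a functional assay on CCRF-CEM cells (Homo sapiens) for inhibition, with a stated time of 48 h (on this read-out lower numbers stand for stronger inhibition of growth and higher numbers for weaker inhibition of growth), compound 2 (`C=CCc1c(O)c(C(=O)/C=C/c2ccccc2)c(OC)c2ccoc12`) gives 2750 nM, and compound 1 (`COc1c(C(=O)/C=C/c2ccc(Cl)cc2)c(O)c(Br)c2occc12`) gives 2660 nM. Compound 2 stands level with compound 1, the two values lying within the scatter of each other. These two compounds differ in more than one place, and the series holds no measured single change to serve as a guide.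

Compound 3 (`C=CCc1c(O)c(C(=O)/C=C/c2ccc(Cl)cc2)c(OC)c2ccoc12`) follows from compound 2 by one change, phenyl to 4-chlorophenyl, with chloro in place of hydrogen on an aromatic carbon, para to a large group: chloro in place of hydrogen on an aromatic carbon. For the measured compounds named here, the only hint available is compound 1, which carries the same 4-chlorophenyl group and gives 2660 nM, close to the value of compound 2 at 2750 nM. On that basis no large move is expected in this assay. The expected outcome is a step within the scatter, leaning slightly toward stronger inhibition of growth: a 1.3-fold lower number from compound 2 to compound 3 (0.10 log units; within the scatter). The estimated value for compound 3 is 2200 nM, with an expected range from 1000 nM to 4500 nM.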

Compound 3, concentration for 50% growth inhibition: 3330 nM
The estimate for compound 3 lay 1.5-fold (0.18 log units) below the measured number; low and high end bracket the measured number.
By their numbers in this assay, from the lowest: compounds 1, 2 and 3 (each within the scatter of the next).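

In this assay, chloro in place of hydrogen on an aromatic carbon, para to a large group, gives a 1.2-fold higher number from compound 2 to compound 3 (0.08 log units; within the scatter), so phenyl and 4-chlorophenyl stand level on this read-out in the setting of compound 2. With the 4-chlorophenyl group held, allyl in place of bromo on an aromatic carbon gives a 1.3-fold higher number from compound 1 to compound 3 (0.10 log units; within the scatter), which places a second kind of step inside the scatter and leaves compounds 1, 2 and 3 level with one another. No supporting data are at hand that would account for these values.

The three compounds cover only a narrow span of this assay, so they do not tell whether any substitution at either place can carry the number beyond the scatter. Open questions are whether an amine or a carboxylic acid in place of chloro, para to the large group, would separate from compound 3, and whether a longer chain in place of allyl would do the same.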